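From 4-methylbenzyl to benzyl: a step near the limit

The source may report more compounds than this note shows. Statements on the series, on what has been measured and on what is new or still open speak of the compounds shown alone.

In a functional assay on THP-1 cells (Homo sapiens) for inhibition, read by sulforhodamine B assay, with a stated time of 48 h (a lower number here means a stronger inhibitor, a higher number a weaker inhibitor), compound 1 (`COc1ccc(C(O)(Cc2ccc(C)cc2)c2cccc3ccccc23)c(OC)c1OC`) gives > 20000 nM, and this is a limit of the assay and not a number. Among the measured compounds shown here, compound 2 (`COc1ccc(/C(=C\c2ccc(F)cc2)c2cccc3ccccc23)c(OC)c1OC`) is the only other compound tested so far, and compound 2 gives a measured 9080 nM.

The next compound to be tested is compound 3 (`COc1ccc(C(O)(Cc2ccccc2)c2cccc3ccccc23)c(OC)c1OC`), which keeps the core of compound 1 but has hydrogen in place of methyl on an aromatic carbon, para to a large group. This turns 4-methylbenzyl into benzyl (hydrogen in place of methyl on an aromatic carbon).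

For the measured compounds named here, no measured pair of compounds differs in just one place, so the data offer no direct guide to the size of this change. In this assay, the expectation is therefore for no step beyond the scatter, in either direction. This expectation rests on compound 1 and its reading of > 20000 nM, so a further limit would be no surprise.

The estimated change is a number no higher from compound 1 to compound 3 (the limit leaves the size open). For compound 3 the expected value is 20000 nM, with an estimated range of 9000 nM to 40000 nM.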

Compound 3, half-maximal inhibitory concentration: 12400 nM
Compound 3: middle estimate off by 1.6-fold (0.21 log units), on the high side, within the range that was stated.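

The pair of compound 1 and compound 3 gives this position its first reading of a single change, and the benzyl compound, compound 3, gives a measured number in this assay, 12400 nM. Hydrogen in place of methyl on an aromatic carbon, para to a large group, amounts to an at least 1.6-fold lower number from compound 1 to compound 3 (0.20 log units; that floor lies within the scatter). The value of compound 1 is a limit of the assay and not a number, so this change can be read only as a floor, with no upper bound on its size: the limit of > 20000 nM in this assay, at which 1 of the 3 values shown sits.

The data therefore leave open whether removing the methyl changes the reading by more than the scatter or hardly at all, and a measured partner for compound 3 with a firm number would be needed to settle it. Also open, on these data alone, is how this place on the ring responds to other groups, such as a methoxy group, a chlorine atom, an amine or a carboxylic acid, since methyl and hydrogen are the only two seen here.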